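The source may hold more compounds than are shown below. What is called first, only, known or untested is meant among the compounds shown, and "the series" means these compounds.

Compound 1, `C=C1CC[C@@H]2[C@](C)(COC(C)=O)[C@H](OC(C)=O)CC[C@@]2(C)[C@H]1CC(Nc1ccc(S(=O)(=O)Nc2nccs2)cc1)C1=CCOC1=O`: 4430 nM
Compound 2, `C=C1CC[C@@H]2[C@](C)(COC(C)=O)[C@H](OC(C)=O)CC[C@@]2(C)[C@H]1CC(Nc1ccc(S(=O)(=O)Nc2ccc(Cl)nn2)cc1)C1=CCOC1=O`: 3370 nM

Both compounds were tested in a functional assay on MDA-MB-468 cells (Homo sapiens) for inhibition, read by sulforhodamine B assay, with a stated time of 48 h (on this read-out higher numbers stand for weaker inhibition of growth and lower numbers for stronger inhibition of growth), where compound 1 gives 4430 nM and compound 2 gives 3370 nM. Compound 1 stands alongside compound 2 rather than apart from it: a 1.3-fold lower number from compound 1 to compound 2 (0.12 log units; within the scatter), so the two cannot be told apart on this read-out.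

The next compound, compound 3, `C=C1CC[C@@H]2[C@](C)(COC(C)=O)[C@H](OC(C)=O)CC[C@@]2(C)[C@H]1CC(Nc1ccc(S(=O)(=O)Nc2ncccn2)cc1)C1=CCOC1=O`, keeps the shared core of compound 1 and changes only the ring on the sulfonamide nitrogen: pyrimidin-2-yl in place of 1,3-thiazol-2-yl on a sulfonamide nitrogen. Among the compounds with values here, the one measured step that bears on this is the move from compound 1 to compound 2, which also swapped the 1,3-thiazol-2-yl group for a six-membered aromatic ring with 2 hetero atoms on that same nitrogen, and gave a 1.3-fold lower number from compound 1 to compound 2 (0.12 log units; within the scatter). With a single comparable step, and one that stayed inside the noise, there is no ground for expecting compound 3 to move beyond the scatter in either direction. For compound 3 the expected step is therefore a 1.1-fold lower number from compound 1 to compound 3 (0.04 log units; within the scatter). Compound 3 is estimated at 4000 nM, with a range from 2000 nM to 8000 nM.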

Compound 3, concentration for total growth inhibition: 3570 nM
For compound 3 the middle estimate is 1.1-fold (0.05 log units) above the measured one; the range from low to high includes it.
By their numbers in this assay, from the lowest: compounds 2, 3 and 1 (each within the scatter of the next).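

In this assay, pyrimidin-2-yl in place of 1,3-thiazol-2-yl on the sulfonamide nitrogen gives a 1.2-fold lower number from compound 1 to compound 3 (0.09 log units; within the scatter) and the change from the chlorine-bearing ring gives a 1.1-fold higher number from compound 2 to compound 3 (0.03 log units; within the scatter) on the same read-out. Within the data shown here, the earlier pair offered only one swap at this position, whereas three different rings can now be compared, and all three pairs remain within the scatter. Among these compounds, neither replacing the five-membered, sulfur-containing ring with a six-membered one nor having the 6-chloropyridazin-3-yl group instead of pyrimidin-2-yl separates the results, and nothing measured here gives a reason for this similarity.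

Going by these compounds, these compounds all carry an aromatic ring containing nitrogen on the sulfonamide nitrogen, so it remains open whether a plain phenyl ring, a simple methyl group or a ring bearing a carboxylic acid would stay as close to them. On these data alone, it is also open whether the same lack of separation would hold in cells other than this one line, or with a different group in place of the acetate esters on the shared core.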